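A Methyl on the Linker Chain: Expected Cell Toxicity

This account rests on a few compounds, and the source may have more. Where it says the series, first, only, none or still open, it means among the compounds named here.

Going by the values given here, compound 1 `COc1ccc2nc(C)cc(OCC(=O)Nc3cc(C)cc(C)c3)c2c1` is the only compound in this set with a numbered result in a toxicity assay on HepG2 cells (Homo sapiens) for inhibition, read by CellTiter-Glo, with a stated time of 48 h (on this read-out lower numbers stand for stronger inhibition and higher numbers for weaker inhibition), where compound 1 gives 20000 nM. Compound 2 `Cc1cc(C)cc(NC(=O)COc2cc(C)nc3ccc(C(F)(F)F)cc23)c1` differs from it by a trifluoromethyl in place of a methoxy on an aromatic carbon. In this assay compound 2 reaches only the limit of the assay, > 100000 nM, and not a number. Among the compounds with values here, the step of an at least 5.0-fold higher number from compound 1 to compound 2 (0.69 log units; beyond the scatter) is the single measured step here, and its size is only a lower bound because it rests on (the limit of > 100000 nM in this assay, at which 1 of the 2 values shown sits).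

Compound 3 `COc1ccc2nc(C)cc(OC(C)C(=O)Nc3cc(C)cc(C)c3)c2c1` has not been measured. Its change from compound 1 is methyl in place of hydrogen on a saturated chain carbon bound to a carbonyl carbon and an oxygen on an aromatic ring, a change on the chain rather than on the aromatic carbon altered in compound 2. Within the data shown here, no measured step touches this place, so no step beyond the scatter is expected in this assay. The expected step is no change at the digits printed from compound 1 to compound 3 (within the scatter). Compound 3 is therefore expected to give about 20000 nM in this assay, within a range from 7000 nM to 60000 nM.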

Compound 3, half-maximal inhibitory concentration: 39800 nM
For compound 3 the middle estimate is 2.0-fold (0.30 log units) below the measured one; the range from low to high includes it.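

Going by these compounds alone, the step of a 2.0-fold higher number from compound 1 to compound 3 (0.30 log units; within the scatter) is the first reading at this place in this assay, and it shows that methyl in place of hydrogen on this saturated chain carbon leaves the number within the scatter. The only other step shown, an at least 5.0-fold higher number from compound 1 to compound 2 (0.69 log units; beyond the scatter), lies on an aromatic carbon and is printed as beyond the scatter, though its size is only a lower bound, so among these compounds only the aromatic change moves the number by more than the scatter, while the chain change does not. Nothing among the data shown gives a cause for the step at the chain carbon.

The compounds shown leave open whether an ethyl, a longer chain or an amine on this same chain carbon would also stay within the scatter of compound 1, since methyl is the only group seen here. Within the data shown here, they also leave open what methyl on this chain carbon would do when trifluoromethyl takes the place of methoxy on the aromatic carbon, as the chain change is seen only on the methoxy compound.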